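The source may report more compounds than this note shows. Statements on the series, on what has been measured and on what is new or still open speak of the compounds shown alone.

Of the compounds shown here, three built on one shared core have been measured so far. Compound 1 `COc1cc(-c2nnc(SCc3cccc(Br)c3)o2)ccc1O` gives 382000 nM in an ADME assay on cells (Mus musculus, strain BALB/c) for cytotoxicity, read by MTT assay, with a stated time of 24 h; a lower number here means that less compound is tolerated, a higher number that more compound is tolerated. Compound 2 `COc1cc(-c2nnc(SCc3ccc(C)cc3)o2)ccc1O` gives 549000 nM in this assay, and compound 3 `COc1cc(-c2nnc(SCc3ccccc3F)o2)ccc1O` gives 474000 nM in this assay. Compound 3 stands second highest of the three numbers; its nearest neighbour is compound 2, and the step of a 1.2-fold lower number from compound 2 to compound 3 (0.06 log units; within the scatter) lies within the scatter, as does the step of a 1.2-fold higher number from compound 1 to compound 3 (0.09 log units; within the scatter). The step of a 1.4-fold higher number from compound 1 to compound 2 (0.16 log units; within the scatter) is within the scatter too, so the three measured numbers offer no separation between them.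

Compound 4 `COc1cc(-c2nnc(SCc3ccc(Cl)cc3)o2)ccc1O` differs from compound 3 in one place: 4-chlorophenyl in place of 2-fluorophenyl on a saturated chain carbon bound to a sulfur. Going by the values given here, the steps that bear on this are the three exchanges of the group on the saturated chain carbon bound to a sulfur, a 1.4-fold higher number from compound 1 to compound 2 (0.16 log units; within the scatter), a 1.2-fold higher number from compound 1 to compound 3 (0.09 log units; within the scatter) and a 1.2-fold lower number from compound 2 to compound 3 (0.06 log units; within the scatter), none of which left the scatter. On that footing, the step of a 1.0-fold lower number from compound 3 to compound 4 (0.00 log units; within the scatter) is expected to remain within the scatter, in no particular direction. Compound 4 is therefore estimated at 470000 nM in this assay, with a range from 250000 nM to 900000 nM.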

Compound 4, half-maximal cytotoxic concentration: 480000 nM
Beside the measured number, compound 4's estimate is 1.0-fold (0.01 log units) below it, within the range that was stated.
By their numbers in this assay, from the lowest: compounds 1, 3, 4 and 2 (each within the scatter of the next).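

In this assay, the exchanges of the group on a saturated chain carbon bound to a sulfur again fail to separate the compounds, with a 1.0-fold higher number from compound 3 to compound 4 (0.01 log units; within the scatter) and a 1.3-fold higher number from compound 1 to compound 4 (0.10 log units; within the scatter). Going by these compounds alone, the step of a 1.1-fold lower number from compound 2 to compound 4 (0.06 log units; within the scatter) is new in kind: chloro in place of methyl on an aromatic carbon is the first change here confined to a single substituent of the phenyl ring, and it too stays within the scatter, so four substituted phenyl groups now give numbers that cannot be told apart. Nothing available explains how closely these numbers agree.

The compounds shown contain only substituted phenyl groups at this position, so it remains open whether an amine, a carboxylic acid or a longer alkyl chain in place of the phenyl ring would leave the scatter. They also leave open whether any change to the shared core would move the number in this assay.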